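The source may hold more compounds than are shown below. What is called first, only, known or untested is meant among the compounds shown, and "the series" means these compounds.

Measured in a functional assay on MC-38 cells (Mus musculus) for antiproliferative activity, read by CCK-8 assay, with a stated time of 48 h; a lower number here means a stronger inhibitor, a higher number a weaker inhibitor:
- Compound 1 `COc1ccc(/C=C\c2cc(OC)c(OC)c(OC)c2)cc1OCc1ccc(CN2CCCCC2C(=O)O)cc1`: 5400 nM
- Compound 2 `COc1ccc(/C=C\c2cc(OC)c(OC)c(OC)c2)cc1OCc1ccc(CNCCO)cc1`: 1200 nM

Compound 1 has the higher of these two numbers, which makes it the weaker inhibitor of the pair. Compound 3 `COc1ccc(/C=C\c2cc(OC)c(OC)c(OC)c2)cc1OCc1ccc(CN2CCCCC2C(=O)NCCNC(=O)OC(C)(C)C)cc1` has not yet been measured. It keeps the core of compound 1 and differs in one place, on a carbonyl carbon, where (2-((tert-butoxycarbonyl)amino)ethyl)amino stands in place of hydroxy: (2-((tert-butoxycarbonyl)amino)ethyl)amino in place of hydroxy on a carbonyl carbon.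

Within the data shown here, only one measured step bears on this change: a 4.5-fold lower number from compound 1 to compound 2 (0.65 log units; beyond the scatter). This step is modest but beyond the usual scatter. It replaces the whole 2-carboxypiperidin-1-yl group with (2-hydroxyethyl)amino, whereas compound 3 loses only the hydroxy of that group and gains a much larger piece. A single step of a different kind is thin evidence, so the direction is uncertain. In this assay, a step towards a lower number is expected, probably smaller than the measured one. The estimated step is a 2.2-fold lower number from compound 1 to compound 3 (0.33 log units; beyond the scatter). The expected value for compound 3 is 2500 nM, with an estimated range of 800 nM to 7000 nM.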

Compound 3, half-maximal inhibitory concentration: 1900 nM
For compound 3 the middle estimate is 1.3-fold (0.12 log units) above the measured one; the range from low to high includes it.
By their numbers in this assay, from the lowest: compounds 2 and 3 (each within the scatter of the next); then compound 1.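

In this assay, the carbonyl carbon on the saturated ring carbon accepts a much larger group than hydroxy: (2-((tert-butoxycarbonyl)amino)ethyl)amino in its place gives a 2.8-fold lower number from compound 1 to compound 3 (0.45 log units; beyond the scatter). The earlier step, a 4.5-fold lower number from compound 1 to compound 2 (0.65 log units; beyond the scatter), replaced the whole 2-carboxypiperidin-1-yl group, so it could not show what the carbonyl substituent alone contributes; this new step shows that a lower number can be reached with the ring kept and only the hydroxy exchanged. Nothing measured here explains why the number falls with this change.

The entering chain has several parts, an amide link, an ethyl spacer and a tert-butoxycarbonyl end, and the compounds shown cannot say which of them accounts for the step. A simple ethylamide, a methyl ester, or the free primary amine left without the tert-butoxycarbonyl group would help separate the effect of losing the hydroxy from the effect of what is attached in its place.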